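The source may hold more compounds than are shown below. What is called first, only, known or untested is meant among the compounds shown, and "the series" means these compounds.

Among the measured compounds shown here, compound 1 `COc1cc(OC)c(-c2nc3cc(/C=C4\SC(=O)NC4=O)ccc3[nH]2)cc1OC` is one of two compounds measured in an ADME assay on HEK-293T cells (Homo sapiens) for inhibition, read by MTT assay, with a stated time of 48 h; on this read-out lower numbers stand for stronger inhibition and higher numbers for weaker inhibition. In this assay compound 1 gives 15300 nM, the highest of the two numbers recorded. Its nearest neighbour is compound 2 `COc1cc(-c2nc3cc(/C=C4\SC(=O)N(Cc5ccccc5)C4=O)ccc3[nH]2)cc(OC)c1OC`, which in this assay gives 8210 nM; the gap between the two values lies within the usual scatter, so the two results cannot be told apart with confidence, and no ordering between compound 1 and compound 2 is claimed.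

Compound 3 `COc1cc(OC)c(-c2nc3cc(/C=C4\SC(=O)N(Cc5cccc(C)c5)C4=O)ccc3[nH]2)cc1OC` has not yet been measured in this assay. It differs from compound 1 in a single place: 3-methylbenzyl in place of hydrogen on an amide-type nitrogen in a ring. For the measured compounds named here, no measured pair in this set isolates this change, so the size of the step rests on expectation alone. Compound 2, which also carries a substituent on that same amide-type nitrogen of its own core, gives 8210 nM, a number that sits within the scatter of compound 1. On that basis compound 3 is expected to show at most a modest shift, a 1.7-fold lower number from compound 1 to compound 3 (0.23 log units; within the scatter), not clearly beyond the scatter. The estimate for compound 3 in this assay is therefore 9000 nM, with a range from 3500 nM to 25000 nM.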

Compound 3, half-maximal inhibitory concentration: 3350 nM
For compound 3 the middle estimate is 2.7-fold (0.43 log units) above the measured one, and the stated range ends above it.
By their numbers in this assay, from the lowest: compound 3; then compounds 2 and 1 (each within the scatter of the next).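

In this assay, 3-methylbenzyl in place of hydrogen on the amide-type nitrogen in the ring gives a 4.6-fold lower number from compound 1 to compound 3 (0.66 log units; beyond the scatter), a modest step but one that lies beyond the scatter. Among the compounds shown here, this pair is the first in the set to isolate a change at this position, and it shows that the amide hydrogen of compound 1 is not needed for inhibition on this read-out, and that a group with a six-membered aromatic ring can sit on this nitrogen and give a lower number. Nothing available explains the size or direction of this step, and no measurement bears on its cause.

The compounds shown leave open whether the step belongs to the benzyl unit as such or to its methyl group, and whether a plain methyl, a longer alkyl chain or a benzyl group carrying a carboxylic acid on this nitrogen would move the number in the same direction. They also leave open whether the same change would give a step of similar size on the core of compound 2.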